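A few compounds are considered here, and "the series" means these few. Any claim that something is new, unique, unknown or untested is made for them only; others in the source may bear on it.

Working notes on the series. Compound 1 `CCC[S+]([O-])c1sc2nc(-c3cccs3)cc(C(=O)O)c2c1N` gives 71 nM in an assay for inhibition of 15-hydroxyprostaglandin dehydrogenase [NAD(+)] (Homo sapiens), read by fluorescence, with a stated time of 15 min, in the presence of a further agent that is not named here; on this read-out lower numbers stand for stronger inhibition and higher numbers for weaker inhibition. Compound 2 `CCCC[S+]([O-])c1sc2nc(-c3nccs3)cc(-c3ccc(COC(=O)CN(C)C)cc3)c2c1N` gives 3.5 nM in this assay. Compound 3 `CCCCSc1sc2nc(-c3cccs3)cc(-c3ccccc3)c2c1N` returns only a limit in this assay, > 80 nM, not a number; (the limit of > 80 nM in this assay, at which 1 of the 3 values shown sits). Compound 4 `CCCCCC[S+]([O-])c1sc2nc(-c3cccs3)cc(-c3ccccc3)c2c1N` differs from compound 3 by a group of 8 heavy atoms (6 carbon, 1 oxygen, 1 sulfur; no ring) in place of a group of 5 heavy atoms (4 carbon, 1 sulfur; no ring), on an aromatic carbon. Within the data shown here, no measured pair isolates this change, so its size is not known from the series. Compound 1 and compound 2 both carry a sulfinyl chain and sit at numbers rather than a limit; compound 3 does not. For compound 4 a move toward stronger inhibition is expected, a step of an at least 2.6-fold lower number from compound 3 to compound 4 (0.42 log units; beyond the scatter), with wide uncertainty. Compound 4 is estimated at 30 nM, between 8 nM and 150 nM.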

Compound 4, half-maximal inhibitory concentration: 18 nM
Compound 4: the middle estimate sits 1.7-fold (0.22 log units) above what was measured, within the range that was stated.
By their numbers in this assay, from the lowest: compound 2; then compound 4; then compound 1. At a limit, above all of these: compound 3.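

The exchange of butylsulfanyl for the group of 8 heavy atoms on this aromatic carbon amounts to an at least 4.4-fold lower number from compound 3 to compound 4 (0.64 log units; beyond the scatter) in this assay. Among these compounds, this is the first pair to isolate a change at this place, and it shows that the change moves the number beyond the scatter. The step is a bound and not a full size: the limit of > 80 nM in this assay, at which 1 of the 4 values shown sits.

The sulfinyl oxygen and the longer chain enter together, and the two effects remain unseparated. From the compounds shown here alone, whether a hexylsulfanyl group on the same core would carry the step, or an octylsulfinyl chain extend it, stays open.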